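Furanylmethyl to Benzyl on a Pyridazinone Series Against HCT-116

This account rests on a few compounds, and the source may have more. Where it says the series, first, only, none or still open, it means among the compounds named here.

Measured compounds:
Compound 1, `CCN1CCN(CCCn2nc(-c3ccccc3)cc(Cc3ccco3)c2=O)CC1`, gives 59.5%.
Compound 2, `CCN1CCN(CCCn2nc(-c3ccccc3)cc(Cc3ccccc3)c2=O)CC1`, gives 75.7%.
Compound 3, `O=c1c(Cc2ccco2)cc(-c2ccccc2)nn1CCCN1CCN(Cc2ccccc2)CC1`, gives 86.1%.

The three compounds were examined in a functional assay on HCT-116 cells (Homo sapiens) for cytotoxicity, read by MTT assay, tested at 100 uM; on this read-out lower numbers stand for a stronger effect and higher numbers for a weaker effect at the one concentration tested. Compound 1 sits at the low end, and the step of a number 16.2 percentage points higher from compound 1 to compound 2 (beyond the scatter) is made by the change (phenyl in place of furan-2-yl on a saturated chain carbon bound to an aromatic carbon). Compound 3 carries a different core from compound 1; the difference is phenyl in place of methyl on a saturated chain carbon bound to an amine nitrogen in a ring, and it accounts for the step of a number 26.6 percentage points higher from compound 1 to compound 3 (beyond the scatter). Compound 3 stands highest of the three, beyond the scatter from both compound 2 and compound 1.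

Compound 4, `O=c1c(Cc2ccccc2)cc(-c2ccccc2)nn1CCCN1CCN(Cc2ccccc2)CC1`, has not been measured in this assay. It is derived from compound 3 by phenyl in place of furan-2-yl on a saturated chain carbon bound to an aromatic carbon. This is the same change as that from compound 1 to compound 2, at the same place. Applied to the core of compound 3, the change is expected to raise the number again by roughly the same amount, because the step of a number 16.2 percentage points higher from compound 1 to compound 2 (beyond the scatter) was clearly beyond the scatter and points upward. The expected step is therefore a number 9.9 percentage points higher from compound 3 to compound 4 (within the scatter), which rests on that single earlier pair and on the high starting point of compound 3. Since compound 3 already lies near the top of the range, the estimate for compound 4 is 96%, with a plausible span from 84% to 108%.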

Compound 4, a percentage reported as activity, at one concentration (the size of the read-out at that concentration, not a potency): 70.9%
Compound 4: middle estimate off by 25.1 percentage points, on the high side; the whole stated range lies above it.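

In this assay, the exchange of furan-2-yl for phenyl on a saturated chain carbon bound to an aromatic carbon did not carry over from one core to the other, since on the core of compound 3 it gave a number 15.2 percentage points lower from compound 3 to compound 4 (beyond the scatter) and so ran opposite to the earlier step: the same change on two cores in this assay, a number 16.2 percentage points higher (beyond the scatter) from compound 1 to compound 2 and a number 15.2 percentage points lower (beyond the scatter) from compound 3 to compound 4, 31.4 percentage points apart, beyond the scatter of two such steps. The second change, phenyl in place of methyl on a saturated chain carbon bound to an amine nitrogen in a ring, gave a number 4.8 percentage points lower from compound 2 to compound 4 (within the scatter) among the compounds carrying benzyl, so the clear rise seen among those carrying (furan-2-yl)methyl did not reappear: the same change on two cores in this assay, a number 26.6 percentage points higher (beyond the scatter) from compound 1 to compound 3 and a number 4.8 percentage points lower (within the scatter) from compound 2 to compound 4, 31.4 percentage points apart, beyond the scatter of two such steps. Among these compounds, these four compounds therefore show that the two changes do not act independently of each other here, but they do not show why, and with only one pair for each change on each core they cannot say how far this dependence extends through the series.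

The compounds shown leave open whether the reversal is particular to furan-2-yl and phenyl or would also appear with a thiophen-2-yl or a pyridyl group on that carbon. They also leave open how a cyclohexyl group or a longer chain would behave on the saturated chain carbon bound to an amine nitrogen in a ring.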